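This account rests on a few compounds, and the source may have more. Where it says the series, first, only, none or still open, it means among the compounds named here.

Measured in a functional assay on MGC-803 cells (Homo sapiens) for cytotoxicity, read by MTT assay, with a stated time of 48 h; on this read-out higher numbers stand for weaker inhibition and lower numbers for stronger inhibition:
- compound 1 (`CC1=NN(C(=O)c2ccc([N+](=O)[O-])cc2)C(c2ccccc2O)C1`) gives 50000 nM
- compound 2 (`CCC(=O)N1N=C(C)CC1c1cc(Br)ccc1O`) gives 50300 nM

Compound 2 stands level with compound 1, the two values lying within the scatter of repeated measurements. Compound 3 (`CC1=NN(C(=O)CCc2ccccc2)C(c2cc(Br)ccc2O)C1`) departs from compound 2 by a single change (phenyl in place of hydrogen on a saturated chain carbon, two bonds along the chain from a carbonyl carbon), with phenyl in place of hydrogen on a saturated chain carbon, two bonds along the chain from a carbonyl carbon, so that ethyl becomes phenethyl. Among the compounds with values here, no measured pair isolates this change, so the expectation is loose. A modest move toward stronger inhibition in this assay is expected (a 2.0-fold lower number from compound 2 to compound 3 (0.30 log units; within the scatter)). Compound 3 is estimated at 25000 nM (expected range 6000 nM to 70000 nM).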

Compound 3, half-maximal inhibitory concentration: 21200 nM
Compound 3: middle estimate off by 1.2-fold (0.07 log units), on the high side, within the range that was stated.
By their numbers in this assay, from the lowest: compound 3; then compounds 1 and 2 (each within the scatter of the next).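

In this assay, the series now has a step at this position: phenyl in place of hydrogen on a saturated chain carbon, two bonds along the chain from a carbonyl carbon, gives a 2.4-fold lower number from compound 2 to compound 3 (0.38 log units; beyond the scatter) and so moves the value modestly toward stronger inhibition. Ethyl to phenethyl thus shows that this chain position accepts a six-membered aromatic ring with no loss in this read-out. Nothing at hand gives a cause for the step. Open, on these data alone, is whether the aromatic ring or the added chain length carries the step, which a cyclohexyl ring or a plain butyl chain in the same place would separate. Also open, as far as these compounds go, is whether a shorter benzyl or a phenyl ring bearing an amine would go further.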